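The compounds below may be only part of what the source reports. "The series", "measured", "known", "first", "only" and "open" are said of these compounds alone.

The measured compounds and their values:

compound 1, `N#Cc1cncc(OC[C@@H]2CCN2)c1`: 0.025 nM
compound 2, `NCc1cncc(OC[C@@H]2CCN2)c1`: 4.4 nM
compound 3, `Clc1ccncc1OC[C@@H]1CCN1`: 260 nM

In an assay on brain for binding affinity to Neuronal acetylcholine receptor; alpha4/beta2 (Rattus norvegicus), read by radioligand binding (a lower number here means a stronger inhibitor, a higher number a weaker inhibitor), compound 1 gives 0.025 nM. Among the compounds with values here, compound 2 gives 4.4 nM, and the step of a 180-fold higher number from compound 1 to compound 2 (2.25 log units; beyond the scatter) is the only single-point step among the measured set. Compound 3 stands highest of the three numbers: its nearest neighbour is compound 2, with a gap well beyond the scatter, and the gap to compound 1 is far larger still.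

Compound 4, `Clc1ccncc1OC[C@H]1CCN1`, is the counterpart of compound 3 with the opposite configuration: the two compounds have the same atoms and bonds and differ only in configuration as drawn: 1 of 1 stereo elements differ; a stereocentre at a saturated ring carbon is drawn S in compound 3 and R in compound 4. No measured step concerns a change of configuration, so the one step shown, a 180-fold higher number from compound 1 to compound 2 (2.25 log units; beyond the scatter), does not bear on it; it concerns a different substituent on the shared core and offers no guide to the size or direction here. Compound 4 is therefore expected, without support from any measured step, to give a higher number, with the step of a 7.7-fold higher number from compound 3 to compound 4 (0.89 log units; beyond the scatter) resting on an assumption rather than on data. The estimate for compound 4 in this assay is 2000 nM, within a range from 300 nM to 15000 nM.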

Compound 4, inhibition constant: 12 nM
Beside the measured number, compound 4's estimate is 170-fold (2.22 log units) above it; the whole stated range lies above it.
By their numbers in this assay, from the lowest: compound 1; then compound 2; then compound 4; then compound 3.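

Going from S to R as drawn at the saturated ring carbon gives a 22-fold lower number from compound 3 to compound 4 (1.34 log units; beyond the scatter) in this assay. Within the data shown here, until this pair, the only step available concerned a substituent on an aromatic carbon, so this is the first sign that configuration at this ring carbon can by itself produce a large change, with R as drawn giving the lower number in this pair. The step can be assigned to configuration alone because nothing else separates the two structures: the fact that compounds 3 and 4 differ only in the configuration as drawn

Going by these compounds, whether R as drawn would also give the lower number with a nitrile or an aminomethyl group in place of the chlorine remains open. So does the size of the step between the two configurations with another group there, such as a methoxy group or a bromine.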